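The compounds below may be only part of what the source reports. "The series", "measured", "known", "first", "only" and "open" are said of these compounds alone.

Two compounds of the series have been run so far in a functional assay on CHO cells for agonist activity at Alpha-1B adrenergic receptor (Homo sapiens), read by FLIPR and calcium flux; a higher number here means that more compound is needed for the effect, a lower number that less compound is needed. Compound 1 `COc1ccc(C2CCc3nc[nH]c3C2)cc1` returns only the assay limit there, > 10000 nM. Compound 2 `COCc1ccccc1C1Cc2nccn2C1` likewise returns only the assay limit in this assay, > 10000 nM. Within the data shown here, compound 2 therefore stands nowhere on a numeric scale: its value is a limit, and the one other value shown is a limit as well, as summed up by the limit of > 10000 nM in this assay, at which 2 of the 2 values shown sit. Among the measured compounds shown here, no pair of measured compounds differs in a single place, so no measured step is available to size the effect of any change.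

Compound 3 `N#Cc1ccccc1C1Cc2nccn2C1` has not yet been measured in this assay. It differs from compound 2 by cyano in place of methoxymethyl on an aromatic carbon, in words, cyano in place of methoxymethyl on an aromatic carbon. For the measured compounds named here, with compound 2 at a limit and no measured step to lean on, the expected change from compound 2 to compound 3 is none beyond the scatter, and the step that the limit leaves unreadable from compound 2 to compound 3 is an estimate only. Compound 3 is expected to give 20000 nM in this assay, within a range from 5000 nM to 100000 nM, most likely again reported as a limit.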

Compound 3, half-maximal effective concentration: > 10000 nM
Compound 3: no number, only a limit (the forecaster's own chance of this, stated with the estimate: 80%); the middle value lies beyond the limit too.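

No step can be read from compound 2 to compound 3 in this assay since both return only a limit, so cyano in place of methoxymethyl stays unsized: the limit of > 10000 nM in this assay, at which 3 of the 3 values shown sit.

The compounds shown leave open whether any member of the series gives a numeric value in this assay and which change in the structure would bring one.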